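Methoxy in place of trifluoromethyl: notes on the series

This account rests on a few compounds, and the source may have more. Where it says the series, first, only, none or still open, it means among the compounds named here.

Measured in a functional assay on NCI-H520 cells (Homo sapiens) for inhibition, read by MTT assay, with a stated time of 48 h, tested at 10 uM; a higher number here means more inhibition at the concentration tested (going by the name of the read-out), a lower number less inhibition:

compound 1, `COc1ccc(C(F)(F)F)cc1Nc1cc(NC(=O)Nc2c(Cl)cccc2Cl)ncn1`, gives 33%
compound 2, `COc1cc(Nc2cc(NC(=O)Nc3c(Cl)cccc3Cl)ncn2)cc(OC)c1`, gives 55.5%
compound 3, `COc1cc(Nc2cc(NC(=O)Nc3c(Cl)cccc3Cl)ncn2)cc(C(F)(F)F)c1`, gives 23.1%

Compound 1 and compound 3 are built from the same atoms joined differently; the difference between the two cores is not broken down here. Their values in this assay lie within the usual scatter of each other, so nothing is made of the gap between them.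

For the measured compounds named here, the one change with a measured step is from compound 3 to compound 2: methoxy in place of trifluoromethyl on an aromatic carbon. In this assay this gives a number 32.4 percentage points higher from compound 3 to compound 2 (beyond the scatter), a step well beyond the scatter and the only large one among the three measured compounds.

Compound 4, `COc1ccc(OC)c(Nc2cc(NC(=O)Nc3c(Cl)cccc3Cl)ncn2)c1`, is not yet measured. It differs from compound 1 by methoxy in place of trifluoromethyl on an aromatic carbon. This is the same kind of change as that from compound 3 to compound 2, not the same change: in compound 2 the entering methoxy is meta to a methoxy group, in compound 4 it is para to a methoxy group. Whether that difference around the place matters is not known from these compounds.

Going by the values given here, the expectation for compound 4 rests on the step from compound 3 to compound 2 because a number 32.4 percentage points higher from compound 3 to compound 2 (beyond the scatter) is the only measured instance of this kind of change. Among the compounds with values here, from compound 1 to compound 4 a step of about a number 22 percentage points higher from compound 1 to compound 4 (beyond the scatter) is expected, kept somewhat smaller than the measured one since only one instance supports it. Compound 4 is thus estimated at 55% in this assay, most likely between 35% and 75%.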

Compound 4, a percentage reported as inhibition, at one concentration (the size of the read-out at that concentration, not a potency): 74%
Compound 4: middle estimate off by 19 percentage points, on the low side; low and high end bracket the measured number.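

In this assay, methoxy in place of trifluoromethyl on an aromatic carbon gives a number 41 percentage points higher from compound 1 to compound 4 (beyond the scatter), and the size of this step agrees with the earlier one on the other core: the same change on two cores in this assay, a number 32.4 percentage points higher (beyond the scatter) from compound 3 to compound 2 and a number 41 percentage points higher (beyond the scatter) from compound 1 to compound 4, 8.6 percentage points apart, within the scatter of two such steps

Within these four compounds the change therefore carries from one core to the other, going the same way on both. The surroundings of the place differ, with the entering methoxy para to a methoxy group in compound 4 but not in compound 2, yet the two steps do not separate beyond the scatter. For the compounds shown here, this is still only two pairs, read in one cell line at one concentration and one time, so it shows neither that the step would hold on a further core nor why the change acts as it does.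

The compounds shown leave open whether the step belongs to methoxy itself or would also appear with another group at the same place, such as an amine, a hydroxyl or a longer alkoxy chain. On these data alone, all four also share the same urea portion, so it remains open whether the step would survive a change there, for instance a carboxylic acid on that part of the molecule.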